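The source may hold more compounds than are shown below. What is called first, only, known or untested is meant among the compounds shown, and "the series" means these compounds.

Of the compounds shown here, three sharing one core have been tested in an ADME assay on cells (Fibroblast, Homo sapiens) for cytotoxicity, read by cell counting, with a stated time of 48 h; on this read-out lower numbers stand for stronger inhibition and higher numbers for weaker inhibition. Compound 1 `Cc1ccc(-n2cc(COc3cccc4cnc(Nc5cccc(Cl)c5)nc34)nn2)c([N+](=O)[O-])c1` gives 21000 nM, and compound 3 `Clc1cccc(Nc2ncc3cccc(OCc4cn(Cc5c(Cl)cccc5Cl)nn4)c3n2)c1` gives 14000 nM. These two numbers cannot be told apart, since the step is a 1.5-fold lower number from compound 1 to compound 3 (0.18 log units; within the scatter). Compound 2 `Clc1ccc(-n2cc(COc3cccc4cnc(Nc5cccc(Cl)c5)nc34)nn2)cc1` returns only a limit, > 25000 nM.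

Compound 4 `COc1cccc(-n2cc(COc3cccc4cnc(Nc5cccc(Cl)c5)nc34)nn2)c1` has not yet been measured. It carries 3-methoxyphenyl in place of 2,6-dichlorobenzyl on an aromatic nitrogen of the five-membered aromatic ring: 3-methoxyphenyl in place of 2,6-dichlorobenzyl on an aromatic nitrogen. The best guides are the other changes at this same place, since compound 1 and compound 2 also carry a substituted phenyl group there. Besides the step already given, the data show an at least 1.7-fold lower number from compound 2 to compound 3 (0.25 log units; that floor lies within the scatter), which is only a floor set by the limit. Neither step gives reason to expect a large shift, so a modest move towards weaker inhibition is the most that can be expected. The estimated change is a 1.6-fold higher number from compound 3 to compound 4 (0.20 log units; within the scatter), and no step beyond the scatter is expected. For compound 4 the expected value is 22000 nM, with an estimated range from 12000 nM to 38000 nM.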

Compound 4, half-maximal inhibitory concentration: 18000 nM
The estimate for compound 4 lay 1.2-fold (0.09 log units) above the measured number, within the range that was stated.
By their numbers in this assay, from the lowest: compounds 3, 4 and 1 (each within the scatter of the next). At a limit, above all of these: compound 2.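

In this assay, putting 3-methoxyphenyl in place of 2,6-dichlorobenzyl on the aromatic nitrogen gives a 1.3-fold higher number from compound 3 to compound 4 (0.11 log units; within the scatter), and putting it in place of 4-methyl-2-nitrophenyl gives a 1.2-fold lower number from compound 1 to compound 4 (0.07 log units; within the scatter). Neither step can be told apart from repeat-measurement noise, even though the first removes both chlorine atoms and brings in a hydrogen-bond acceptor. This position now has three exact numbers, and each lies within the scatter of the next, so none of these changes shows a real effect on the read-out.

Compound 2 remains a limit: the limit of > 25000 nM in this assay, at which 1 of the 4 values shown sits. Putting 3-methoxyphenyl in place of 4-chlorophenyl gives an at least 1.3-fold lower number from compound 2 to compound 4 (0.14 log units; that floor lies within the scatter), which is only a floor set by that limit. Every group shown at this nitrogen holds a six-membered aromatic ring of carbon, so it stays open whether an amine, a carboxylic acid or an open alkyl chain there would move the number beyond the scatter.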